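This account rests on a few compounds, and the source may have more. Where it says the series, first, only, none or still open, it means among the compounds named here.

Measured so far in a functional assay on PC-3 cells (Homo sapiens) for antiproliferative activity, read by MTT assay, with a stated time of 48 h; a lower number here means a stronger inhibitor, a higher number a weaker inhibitor:

Compound 1, `CCN1C(=O)C(O)(Cc2nnn[nH]2)c2cc(Cl)ccc21`, gives 79300 nM.
Compound 2, `CCN1C(=O)C(O)(Cc2nnn[nH]2)c2cc(Br)ccc21`, gives only a limit of the assay, > 100000 nM.
Compound 3, `Cc1ccc2c(c1)C(O)(Cc1nnn[nH]1)C(=O)N2C`, likewise gives only a limit of the assay, > 100000 nM.

All three share one core, a ring-fused amide bearing a hydroxyl and a tetrazole-bearing side chain, and differ only in the substituent on the aromatic ring and in the group on the amide-type nitrogen. Compound 3 therefore stands at the limit of this assay, with no number of its own; it is one of the two compounds described by the limit of > 100000 nM in this assay, at which 2 of the 3 values shown sit.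

Compound 4, `CCN1C(=O)C(O)(Cc2nnn[nH]2)c2cc(C)ccc21`, is the next compound. It differs from compound 3 by methyl in place of hydrogen on a saturated chain carbon bound to an amide-type nitrogen in a ring.

For the measured compounds named here, only one measured step exists between these compounds: an at least 1.2-fold higher number from compound 1 to compound 2 (0.10 log units; that floor lies within the scatter), a change of the aromatic halogen, not of the group on the amide-type nitrogen, and a step that lies within the scatter. Going by the values given here, no measured step touches the change from compound 3 to compound 4, so the expectation rests on the weak level of the whole set. The expected step is a number no higher from compound 3 to compound 4 (the limit leaves the size open), none beyond the scatter. Compound 4 is therefore expected to give about 100000 nM in this assay, in the range 45000 nM to 220000 nM, most likely again only a limit.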

Compound 4, half-maximal inhibitory concentration: > 100000 nM
Compound 4 was reported as a limit (the forecaster's own chance of this, stated with the estimate: 70%); the middle value lies on the limit itself.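

Replacing methyl with ethyl on the saturated chain carbon bound to the amide-type nitrogen in a ring leaves compound 4 at a limit in this assay, so this change brings no readable gain; the steps from compound 3 and from compound 2 to compound 4 cannot be read, with limits at both ends. Exchanging chloro for methyl on an aromatic carbon gives an at least 1.2-fold higher number from compound 1 to compound 4 (0.10 log units; that floor lies within the scatter), so this swap on the ring shows no change beyond the scatter. The series now gathers at a single point: the limit of > 100000 nM in this assay, at which 3 of the 4 values shown sit.

Still open, from the compounds shown here alone, is whether a longer chain, such as propyl, or a benzyl group in place of the ethyl would bring a readable number in this assay. Equally open, going by these compounds, is whether an amine or a carboxylic acid in place of the methyl on the aromatic carbon would do so.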